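The compounds below may be only part of what the source reports. "The series", "measured", "known", "first", "only" and "open" are said of these compounds alone.

Working notes on the series, cytotoxicity readings. Three compounds have been run in an ADME assay on HEK293 cells (Homo sapiens) for cytotoxicity, with a stated time of 72 h; a higher number here means that more compound is needed for the effect, a lower number that less compound is needed. Compound 1 `COc1ccc(NC(=O)Nc2cc(C)nc3ccccc23)cc1` carries a methoxy on the aromatic ring outside the shared core. In this assay compound 1 reaches only the assay limit, > 25000 nM, so no number stands for it. Compound 2 `Cc1cc(NC(=O)Nc2ccccc2C(F)(F)F)c2ccccc2n1` likewise gives only a limit in this assay, > 25000 nM. Compound 3 `Cc1cc(NC(=O)Nc2cccc(C(N)=O)c2)c2ccccc2n1` also sits at the limit, > 25000 nM. Going by the values given here, because of the limit of > 25000 nM in this assay, at which 3 of the 3 values shown sit, compound 1 stands exactly where every measured compound stands: no value below the limit has been seen, and no step between measured compounds can be computed.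

The next compound, compound 4 `Cc1cc(NC(=O)Nc2ccc(F)cc2)c2ccccc2n1`, differs from compound 1 by fluoro in place of methoxy on an aromatic carbon; the change sits on an aromatic carbon of a six-membered aromatic ring of carbon only, para to a large group. All three measured values are limits, so no direction beyond the scatter can be read from them. The step of a number no higher from compound 1 to compound 4 (the limit leaves the size open) is expected to be none beyond the scatter. Compound 4 is estimated at 25000 nM in this assay, within 12000 nM to 50000 nM, most likely again reported as a limit.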

Compound 4, half-maximal effective concentration: > 25000 nM
Compound 4 ended at the assay's limit; the forecaster's own chance of this, stated with the estimate: 80%; the middle value lies on the limit itself.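

No step from compound 1 to compound 4 can be read, because both values are limits and not numbers: the limit of > 25000 nM in this assay, at which 4 of the 4 values shown sit.

The compounds shown leave open how far each lies from that limit, and whether any change on the aromatic ring outside the shared core would give a readable value.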